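The source may report more compounds than this note shows. Statements on the series, on what has been measured and on what is new or still open speak of the compounds shown alone.

Working notes on the series. Compound 1 `Nc1ccc(/C=C2\SC(=O)N(Cc3ccc(C(F)(F)F)cc3)C2=O)cc1` is the reference here; in a functional assay on FM3A cells (Mus musculus) for cytotoxicity, read by cell counting, with a stated time of 2 days (on this read-out higher numbers stand for weaker inhibition and lower numbers for stronger inhibition), compound 1 gives 134000 nM. It is the only number shown, the one further value being a limit. Compound 2 `Nc1cccc(/C=C2\SC(=O)N(Cc3ccc(C(F)(F)F)cc3)C2=O)c1` carries 3-aminophenyl in place of 4-aminophenyl; compound 2 gives > 250000 nM, a limit of the assay and not a number. That step, an at least 1.8-fold higher number from compound 1 to compound 2 (0.27 log units; that floor lies within the scatter), runs to the limit of > 250000 nM in this assay, at which 1 of the 2 values shown sits, so its size is known only as a floor, and that floor lies within the scatter.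

Compound 3 `Nc1ccc(/C=C2\SC(=O)N(Cc3ccccc3)C2=O)cc1` differs from compound 1 elsewhere: hydrogen in place of trifluoromethyl on an aromatic carbon. Among the compounds with values here, none of the measured steps touches this position, since the only step recorded moves the amino group on the other ring. No size or direction for the trifluoromethyl change can therefore be read from the data, and the expectation in this assay is a step not beyond the scatter. The step expected is no change at the digits printed from compound 1 to compound 3 (within the scatter). Compound 3 is accordingly estimated at 134000 nM, with a range from 50000 nM to 300000 nM, and a limit rather than a number remains possible.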

Compound 3, half-maximal inhibitory concentration: 24000 nM
Beside the measured number, compound 3's estimate is 5.6-fold (0.75 log units) above it; measured number below the stated range.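

In this assay the aromatic carbon that carries trifluoromethyl in compound 1 proves to be a position that moves the read-out, with a 5.6-fold lower number from compound 1 to compound 3 (0.75 log units; beyond the scatter). With hydrogen in place of trifluoromethyl, inhibition of the cells is stronger, and this is the only step shown so far that is known to lie beyond the scatter, since the step on the amino group is known only as a floor that lies within it. Nothing in the data shown accounts for the size or direction of this step.

On these data alone, this position rests on a single pair of compounds, so it remains open whether the same change would act in the same direction on the 3-aminophenyl series of compound 2. As far as these compounds go, it also remains open whether fluorine, chlorine, methyl or methoxy on the same aromatic carbon would read closer to the hydrogen of compound 3 or to the trifluoromethyl of compound 1.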